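Nitro in place of hydrogen on compound 1: tolerance outlook

The source may report more compounds than this note shows. Statements on the series, on what has been measured and on what is new or still open speak of the compounds shown alone.

Measured so far:
compound 1, `COc1ccc(-c2nc3cc(Cl)c(Cl)cc3[nH]2)cc1`: in an ADME assay on MT4 cells (Homo sapiens) for cytotoxicity, read by MTT assay, with a stated time of 96 h (a higher number here means that more compound is tolerated, a lower number that less compound is tolerated), compound 1 gives 1000 nM
compound 2, `Oc1ccc(-c2nc3cc(Cl)c(Cl)cc3[nH]2)cc1`: in this assay compound 2 gives 12000 nM

For the measured compounds named here, compound 1 stands at the lowest of the two numbers; its only neighbour is compound 2, reached by a 12-fold higher number from compound 1 to compound 2 (1.08 log units; beyond the scatter). That single step puts hydrogen in place of methyl on an oxygen on an aromatic ring and tells nothing about other positions on the shared core.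

Compound 3, `COc1ccc(-c2nc3cc(Cl)c(Cl)cc3[nH]2)c([N+](=O)[O-])c1`, differs from compound 1 by nitro in place of hydrogen on an aromatic carbon. Going by the values given here, the methoxy group is kept, so the one measured step does not bear on this change, and no nitro-bearing analogue has been measured. With nothing to indicate a direction, the expectation for this assay is no step beyond the scatter, a 1.2-fold higher number from compound 1 to compound 3 (0.08 log units; within the scatter). Compound 3 is therefore estimated at 1200 nM, with a range from 400 nM to 4000 nM.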

Compound 3, half-maximal cytotoxic concentration: 2000 nM
Compound 3: the middle estimate sits 1.7-fold (0.22 log units) below what was measured; measured number inside the range.
By their numbers in this assay, from the lowest: compounds 1 and 3 (each within the scatter of the next); then compound 2.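

Nitro in place of hydrogen on the aromatic carbon ortho to a large group gives a 2.0-fold higher number from compound 1 to compound 3 (0.30 log units; within the scatter) in this assay and is the first reading at this position. For the compounds shown here, the change adds a group of 3 heavy atoms and still stays inside the scatter, whereas hydrogen in place of methyl on the oxygen gives a 12-fold higher number from compound 1 to compound 2 (1.08 log units; beyond the scatter) and remains the only step beyond it. Nothing measured accounts for either step.

Going by these compounds, whether this holds for groups other than nitro remains open, and an amine or a carboxylic acid on the same aromatic carbon would show whether the position stays as quiet. Also open, on these data alone, is how nitro behaves on compound 2, where the oxygen carries hydrogen in place of methyl, and whether the two changes simply add.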